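A few compounds are considered here, and "the series" means these few. Any claim that something is new, unique, unknown or untested is made for them only; others in the source may bear on it.

Measured compounds:
Compound 1, `CCCCCC(=O)Nc1cc(-c2ccccc2)c(-c2ccccc2)nn1`: > 300000 nM
Compound 2, `CCCCCCS(=O)(=O)c1cc(-c2ccccc2)c(-c2ccccc2)nn1`: 60000 nM

Both compounds share the same core and differ only in the side group attached to it. In an assay on microsomes from liver for inhibition of sterol O-acyltransferase 1 (Rattus norvegicus) (on this read-out lower numbers stand for stronger inhibition and higher numbers for weaker inhibition), compound 1 reaches no number at all; its value is a limit of the assay, as the limit of > 300000 nM in this assay, at which 1 of the 2 values shown sits, records. Among the measured compounds shown here, compound 2 is therefore the only compound with a real number in this assay, and the one other value shown is a limit rather than a number. The measured step of an at least 5.0-fold lower number from compound 1 to compound 2 (0.69 log units; beyond the scatter) exchanges one whole side group for another of a different kind.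

Compound 3, `CCCCCCCCS(=O)(=O)c1cc(-c2ccccc2)c(-c2ccccc2)nn1`, keeps the side group of compound 2 and lengthens its chain: ethyl in place of hydrogen on a saturated chain carbon, six bonds along the chain from a sulfonyl sulfur. For the measured compounds named here, none of the measured steps touches a change of this kind, since the only one available swaps groups rather than extending a chain, so there is nothing here that points in either direction. The expectation for compound 3 is therefore a step of a 1.3-fold lower number from compound 2 to compound 3 (0.12 log units; within the scatter) that stays within the usual scatter. Compound 3 is estimated at 45000 nM, with a range from 12000 nM to 180000 nM.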

Compound 3, half-maximal inhibitory concentration: 36000 nM
Compound 3: middle estimate off by 1.3-fold (0.10 log units), on the high side; low and high end bracket the measured number.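

Putting ethyl in place of hydrogen on a saturated chain carbon, six bonds along the chain from a sulfonyl sulfur, gives a 1.7-fold lower number from compound 2 to compound 3 (0.22 log units; within the scatter) in this assay for this pair. The earlier step exchanged one whole side group for another, whereas this one alters only the far part of the chain and leaves the sulfonyl group and the shared core as they were. It shows that the read-out can stay within ordinary repeat variation when the chain on the sulfonyl group is extended by this much, and nothing available offers an explanation for this particular result.

Going by these compounds, two chain lengths do not make a trend, so it stays open whether a shorter butyl chain or a much longer chain would move the number beyond the scatter. Also open, on these data alone, is how this assay would respond to a chain ending in an amine or a carboxylic acid, or to a chain carrying a phenyl ring at its far end.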